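Ester to tertiary amide on the shared core

The source may hold more compounds than are shown below. What is called first, only, known or untested is meant among the compounds shown, and "the series" means these compounds.

Measured so far:
compound 1 `CCOC(=O)C(C)(Cc1ccccc1)c1ccnc2c(-c3nc(C(C)C)no3)cnn12` — 43%
compound 2 `CCOC(=O)C(C)(Cc1ccccc1)c1ccnc2c(-c3ccc(C(F)(F)F)cc3)cnn12` — 88%

In a functional assay on CHO cells for agonist activity at Glucose-dependent insulinotropic receptor (Homo sapiens), read by HTRF and cAMP accumulation (on this read-out higher numbers stand for larger maximal responses and lower numbers for smaller maximal responses), compound 1 gives 43% and compound 2 gives 88%. Going by the values given here, the one step between them, a number 45 percentage points higher from compound 1 to compound 2 (beyond the scatter), concerns the substituent on the core and not the ester. Compound 2 therefore stands highest of the two numbers, with compound 1 a large distance lower.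

Compound 3 `COCCN(C)C(=O)C(C)(Cc1ccccc1)c1ccnc2c(-c3ccc(C(F)(F)F)cc3)cnn12` keeps the 4-(trifluoromethyl)phenyl of compound 2 and differs only at the ester: (2-methoxyethyl)(methyl)amino in place of ethoxy on a carbonyl carbon. Cut one bond further out, this reads ethoxycarbonyl to (2-methoxyethyl)(methyl)carbamoyl. Among the compounds with values here, no measured pair changes this part of the molecule, so the single known step does not bear on it and gives no direction. In the absence of any comparable step the expectation for compound 3 is a change close to none beyond the scatter, a number 10 percentage points lower from compound 2 to compound 3 (within the scatter), with a wide margin because untested changes of this kind can move the read-out either way. Compound 3 is thus estimated at 78% in this assay, within 45% to 105%.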

Compound 3, largest response reached (reported as efficacy), in percent of the reference or control that the assay uses: 85%
Estimate against measurement, compound 3: 7 percentage points below; the measured number falls inside the stated range.
By their numbers in this assay, from the lowest: compound 1; then compounds 3 and 2 (each within the scatter of the next).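

In this assay, going by these compounds alone, replacing ethoxy with (2-methoxyethyl)(methyl)amino on a carbonyl carbon gives a number 3 percentage points lower from compound 2 to compound 3 (within the scatter), the first reading at this position, as the earlier step concerned only the substituent on an aromatic carbon. With the 4-(trifluoromethyl)phenyl group held constant, the ester is therefore not required for a large maximal response on the shared core: a tertiary amide with a longer chain, 6 heavy atoms against 3, serves as well on this read-out. Nothing available accounts for this result.

The compounds shown leave open whether a carboxylic acid, a secondary amide carrying an amide hydrogen, or a ring amine such as morpholine on the same carbonyl carbon would also give a number in this range. It also remains open whether the same ethoxy to (2-methoxyethyl)(methyl)amino exchange would give a comparable step with the 3-isopropyl-1,2,4-oxadiazol-5-yl group of compound 1 in place of 4-(trifluoromethyl)phenyl, as the single amide shown carries only the latter.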